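A few compounds are considered here, and "the series" means these few. Any claim that something is new, unique, unknown or untested is made for them only; others in the source may bear on it.

Measured so far:
- compound 1 `CN1CCN(c2ccc(Nc3ncc4nc(Nc5ccc(F)cc5)n([C@H]5CCCN(S(=O)(=O)C6CC6)C5)c4n3)cc2)CC1`: 1320 nM in a functional assay on A549 cells (Homo sapiens) for antiproliferative activity, read by MTT assay, with a stated time of 72 h; a lower number here means a stronger inhibitor, a higher number a weaker inhibitor
- compound 2 `CN1CCN(c2ccc(Nc3ncc4nc(Nc5ccc(F)cc5)n([C@H]5CCCNC5)c4n3)cc2)CC1`: "not determined" (no result reported) in this assay

Compound 2 stands without a number: in this assay compound 2 was not determined, so the bare ring amine has no anchor. Compound 1 is the only measured point and gives 1320 nM in this assay. Compound 3 `CN1CCN(c2ccc(Nc3ncc4nc(Nc5ccc(F)cc5)n([C@H]5CCCN(C(=O)CO)C5)c4n3)cc2)CC1` differs from compound 2 by (hydroxymethyl)carbonyl in place of hydrogen on an amine nitrogen in a ring. Going by the values given here, no step between measured compounds exists, so no direction can be read from the data; the expectation rests on compound 1 alone, with a step in this assay of no more than the usual scatter either way. Compound 3 is estimated at 1100 nM in this assay, within 300 nM to 4500 nM.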

Compound 3, half-maximal inhibitory concentration: 830 nM
Compound 3: the middle estimate sits 1.3-fold (0.12 log units) above what was measured, within the range that was stated.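

In this assay, (hydroxymethyl)carbonyl in place of cyclopropylsulfonyl on the ring amine nitrogen gives a 1.6-fold lower number from compound 1 to compound 3 (0.20 log units; within the scatter) and this lies within the scatter. Compound 1 and compound 3 therefore read alike, so this nitrogen has now carried two different groups without a separable difference. No measurement at hand offers an explanation for this result.

With no result for compound 2, the steps from the free ring amine to either group cannot be read. From the compounds shown here alone, whether an acetyl group or a longer chain ending in a carboxylic acid would read differently at this nitrogen remains open.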